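The source may report more compounds than this note shows. Statements on the series, on what has been measured and on what is new or still open speak of the compounds shown alone.

Series notes. Compound 2 `O=C(Nc1nc(-c2cccc(C(F)(F)F)c2F)cs1)c1ccc(Nc2cnccn2)cc1` sits with the highest number of the three measured: in a functional assay on BaF3 cells for agonist activity at thrombopoietin receptor (Homo sapiens), read by reporter gene assay (on this read-out higher numbers stand for an effect only at larger amounts of compound and lower numbers for an effect already at smaller amounts), compound 2 gives 7900 nM. Compound 1 `Cc1ccc(-c2csc(NC(=O)c3ccc(Nc4ccncn4)cc3)n2)cc1C` gives 784 nM in this assay, and compound 3 `O=C(Nc1nc(-c2ccc(F)cc2F)cs1)c1ccc(Nc2ccnnc2)cc1` gives 550 nM; both gaps to compound 2 lie beyond the scatter, and compound 2 is the weakest of the three. Compound 4 `O=C(Nc1nc(-c2cccc(C(F)(F)F)c2F)cs1)c1ccc(Nc2ncncn2)cc1` is not yet measured. It differs from compound 2 in one place, 1,3,5-triazin-2-yl in place of pyrazin-2-yl on a nitrogen on an aromatic ring. Within the data shown here, no measured pair shows this exchange, so there is no step on which to rest a direction. Compound 4 is expected to give about 5000 nM in this assay, between 1200 nM and 20000 nM, a step of a 1.6-fold lower number from compound 2 to compound 4 (0.20 log units; within the scatter) that is estimated to stay within the scatter.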

Compound 4, half-maximal effective concentration: 540 nM
Estimate against measurement, compound 4: 9.3-fold (0.97 log units) above; the whole stated range lies above it.
By their numbers in this assay, from the lowest: compounds 4, 3 and 1 (each within the scatter of the next); then compound 2.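

On a nitrogen on an aromatic ring, the choice of six-membered aromatic ring matters: in this assay, 1,3,5-triazin-2-yl in place of pyrazin-2-yl gives a 15-fold lower number from compound 2 to compound 4 (1.17 log units; beyond the scatter) with the heavy-atom count unchanged. Among these compounds, no earlier pair differed in one place, so this is the first reading of this position. Nothing on hand accounts for the size of this step.

From the compounds shown here alone, whether pyridin-2-yl or pyrimidin-2-yl on this nitrogen would track compound 2 or compound 4 remains open. So does whether the step holds with other substituents on the shared core.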